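This account rests on a few compounds, and the source may have more. Where it says the series, first, only, none or still open, it means among the compounds named here.

Measured so far in a functional assay, with a stated time of 30 min; on this read-out lower numbers stand for stronger inhibition and higher numbers for weaker inhibition:
compound 1 `COc1ccc(C2CC(=NOC(=O)c3ccc([N+](=O)[O-])cc3)CC(c3ccc(OC)cc3)N2C)cc1` gives 280000 nM
compound 2 `COc1ccc(C2CC(=NOC(=O)c3ccc(O)cc3)CC(c3ccc(OC)cc3)N2C)cc1` gives 25000 nM
compound 3 `COc1ccc(C2CC(=NOC(=O)c3cc(O)cc(O)c3)CC(c3ccc(OC)cc3)N2C)cc1` gives 19000 nM

Compound 3 holds the lowest number of the three, but its gap to compound 2 is small: a 1.3-fold lower number from compound 2 to compound 3 (0.12 log units; within the scatter), within the scatter, so nothing separates these two. The two large steps both start from compound 1: an 11-fold lower number from compound 1 to compound 2 (1.05 log units; beyond the scatter) and a 15-fold lower number from compound 1 to compound 3 (1.17 log units; beyond the scatter).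

Compound 4 `COc1ccc(C(=O)ON=C2CC(c3ccc(OC)cc3)N(C)C(c3ccc(OC)cc3)C2)cc1` differs from compound 3 only in the aryl on the carbonyl carbon: 4-methoxyphenyl in place of 3,5-dihydroxyphenyl on a carbonyl carbon. Among the measured compounds shown here, no measured step covers this exact exchange. The steps from compound 1 show that the substituent on this ring can move the number a great deal, while the step from compound 2 to compound 3 shows that trading one hydroxy pattern for another does not. Both of the lower measured numbers belong to rings carrying hydroxy groups; compound 4 carries none, and a methoxy on this ring has not been tried in the series. For compound 4 a moderate rise in the number is therefore expected, a 3.2-fold higher number from compound 3 to compound 4 (0.50 log units; beyond the scatter). Compound 4 is estimated at 60000 nM, with a range from 15000 nM to 250000 nM in this assay.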

Compound 4, half-maximal inhibitory concentration: 68000 nM
Compound 4: the middle estimate sits 1.1-fold (0.05 log units) below what was measured; the measured number falls inside the stated range.
By their numbers in this assay, from the lowest: compounds 3 and 2 (each within the scatter of the next); then compound 4; then compound 1.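

In this assay, putting methyl on the oxygen of the ring hydroxy is a modest change but one beyond the scatter (a 2.7-fold higher number from compound 2 to compound 4 (0.43 log units; beyond the scatter)), so at this position methoxy and hydroxy are not interchangeable. The methoxy ring also falls between the earlier extremes, above the hydroxy-bearing rings (a 3.6-fold higher number from compound 3 to compound 4 (0.55 log units; beyond the scatter)) and below the nitro ring (a 4.1-fold lower number from compound 1 to compound 4 (0.61 log units; beyond the scatter)), so a ring without a hydroxy group need not stand as high as the nitro ring, while across these four compounds the two hydroxy-bearing rings still hold the lowest numbers. No measurement at hand accounts for this order.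

Going by these compounds, it remains open whether an amino group or a carboxylic acid on this ring would fall with the hydroxy-bearing rings, with the methoxy ring or with the nitro ring, and whether an unsubstituted phenyl would give a baseline for reading all these steps. Also open, on these data alone, is whether an ethoxy group would extend the step seen for methoxy, and whether any of these ring effects would hold with an amide in place of the ((4-methoxyphenyl)carbonyl)oxy link.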